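Working notes on three measured compounds and one unmeasured analogue

This account rests on a few compounds, and the source may have more. Where it says the series, first, only, none or still open, it means among the compounds named here.

Measured so far:
compound 1 `CC(=O)OC[C@@H]1O[C@H](COCc2ccccc2)[C@@H](OCc2ccccc2)[C@H](OCc2ccccc2)[C@H]1OC(C)=O` — "not active" (no number reported)
compound 2 `O[C@@H]1[C@@H](OCc2ccccc2)[C@H](OCc2ccccc2)[C@@H](COCc2ccccc2)O[C@H]1CC1CC1` — "not active" (no number reported)
compound 3 `CC1(C)OC[C@@H]2O[C@H](COCc3ccccc3)[C@@H](OCc3ccccc3)[C@H](OCc3ccccc3)[C@H]2O1` — 12500 nM

In a functional assay on HL-60 cells (Homo sapiens) for antiproliferative activity, read by MTT assay (on this read-out lower numbers stand for stronger inhibition and higher numbers for weaker inhibition), compound 1 gives "not active" (no number reported) and compound 2 gives "not active" (no number reported). Compound 3 gives 12500 nM, and it is the only entry with a single number. Compound 2 therefore stands without a number, one of two such entries, and nothing places it above or below compound 3 on the numbers shown.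

Compound 4 `CC(C)C[C@@H]1O[C@H](COCc2ccccc2)[C@@H](OCc2ccccc2)[C@H](OCc2ccccc2)[C@H]1O` is the analogue that differs from compound 2 in one place: isopropyl in place of cyclopropyl on a saturated chain carbon bound to a saturated ring carbon. Among the measured compounds shown here, no step between measured compounds that differ in one place is available, so no measured step size guides this change. The expectation for this assay is a step of no direction, within the usual scatter, with compound 4 remaining near where compound 2 stands. The estimate for compound 4 in this assay is 40000 nM, with a range from 8000 nM to 200000 nM, and a fair chance that only a limit and no number is reported.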

Compound 4, half-maximal inhibitory concentration: 8500 nM
For compound 4 the middle estimate is 4.7-fold (0.67 log units) above the measured one, and the stated range covers the measured number.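

In this assay compound 2 gives "not active" (no number reported) and compound 4 gives 8500 nM and no step can be read between the two. The compounds shown leave open what size of change isopropyl in place of cyclopropyl carries. No supporting evidence bears on this result.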